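The source may hold more compounds than are shown below. What is called first, only, known or untested is meant among the compounds shown, and "the series" means these compounds.

Compound 2 `CC1CCCCN1CCCOc1ccc2c(c1)C(=O)N(C)CC2` stands highest of the two numbers obtained in an assay on cerebellum for displacement of a labelled ligand from histamine H1 receptor (Cavia porcellus), read by scintillation counting, with a stated time of 60 min (on this read-out higher numbers stand for weaker inhibition and lower numbers for stronger inhibition), where compound 2 gives 165 nM and compound 1 `CN1CCc2ccc(OCCCN3CCCC3)cc2C1=O` gives 39 nM. Going by the values given here, the only measured step, a 4.2-fold higher number from compound 1 to compound 2 (0.63 log units; beyond the scatter), is the one that bears here. Compound 3 `CN1CCc2ccc(OCCCN3CCC(O)C3)cc2C1=O` differs from compound 2 by 3-hydroxypyrrolidin-1-yl in place of 2-methylpiperidin-1-yl on a saturated chain carbon, three bonds along the chain from an oxygen on an aromatic ring. Among the compounds with values here, this returns the five-membered ring of compound 1 while bringing in a hydroxyl that has no precedent. A lower number is therefore expected, roughly a 2.8-fold lower number from compound 2 to compound 3 (0.44 log units; beyond the scatter), with the hydroxyl leaving the size uncertain. Compound 3 is estimated at 60 nM, range 20 nM to 180 nM.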

Compound 3, inhibition constant: 112 nM
Estimate against measurement, compound 3: 1.9-fold (0.27 log units) below; the measured number falls inside the stated range.
By their numbers in this assay, from the lowest: compound 1; then compounds 3 and 2 (each within the scatter of the next).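

In this assay, hydroxy in place of hydrogen on a saturated ring carbon gives a 2.9-fold higher number from compound 1 to compound 3 (0.46 log units; beyond the scatter), the first sign that the pyrrolidin-1-yl ring at this position is sensitive to substitution. Exchanging 2-methylpiperidin-1-yl for 3-hydroxypyrrolidin-1-yl gives a 1.5-fold lower number from compound 2 to compound 3 (0.17 log units; within the scatter), so the five-membered ring carrying the hydroxyl does not separate from the six-membered ring carrying the methyl. Nothing available explains either step.

On these data alone, how a methoxy group or an amine on the same ring carbon would compare remains open, as does the reading for unsubstituted piperidin-1-yl.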